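This account rests on a few compounds, and the source may have more. Where it says the series, first, only, none or still open, it means among the compounds named here.

Working notes on the series in an ADME assay on Caco-2 cells (Homo sapiens) for permeability, read by LC-MS, in the apical to basolateral direction, with a stated time of 60 min, at pH 6.5 (on this read-out higher numbers stand for higher permeability and lower numbers for lower permeability), start from three measured compounds. Compound 1 `O=C(NCc1cc(Cl)ccc1-n1cnnn1)[C@@H]1C[C@@H]2C[C@@H]2N1C(=O)[C@H](O)Cn1cccn1` gives 0.45 10^-6 cm/s and is the lowest of the three. Compound 2 `O=C([C@H](O)c1ccccc1)N1CC[C@@H]2C[C@@]21C(=O)NCc1cc(Cl)ccc1-n1cnnn1` gives 2.6 10^-6 cm/s and compound 3 `O=C(NCc1cc(Cl)ccc1-n1cnnn1)[C@@H]1C[C@H]2C[C@H]2N1C(=O)[C@H](O)CC1CC1` gives 6.9 10^-6 cm/s and both stand beyond the scatter above compound 1. No two of these compounds differ in one place only, so no direct single-change step is available and any expectation rests on indirect comparison.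

Compound 4 `CC(C)(C)[C@@H](O)C(=O)N1[C@H](C(=O)NCc2cc(Cl)ccc2-n2cnnn2)C[C@@H]2C[C@@H]21` departs from compound 1 with tert-butyl in place of (1H-pyrazol-1-yl)methyl on a saturated chain carbon bound to a carbonyl carbon and an oxygen on a saturated carbon, counted as tert-butyl in place of (1H-pyrazol-1-yl)methyl on a saturated chain carbon bound to a carbonyl carbon and an oxygen on a saturated carbon in full. Compound 3 has no pyrazole in this side chain and gives 6.9 10^-6 cm/s in this assay and that value is the main basis for expecting a rise. The expected step is an increase beyond the scatter, estimated as a 16-fold higher number from compound 1 to compound 4 (1.19 log units; beyond the scatter) on this indirect basis. Compound 4 is estimated at 7 10^-6 cm/s with an expected range of 3 10^-6 cm/s to 15 10^-6 cm/s as the working figure.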

Compound 4, apparent permeability: 16 10^-6 cm/s
Estimate against measurement, compound 4: 2.3-fold (0.36 log units) below, and the stated range ends below it.
By their numbers in this assay, from the lowest: compound 1; then compound 2; then compound 3; then compound 4.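

In this assay the series now has its first comparison that differs in one place: tert-butyl in place of (1H-pyrazol-1-yl)methyl on a saturated chain carbon bound to a carbonyl carbon and an oxygen on a saturated carbon gives a 36-fold higher number from compound 1 to compound 4 (1.55 log units; beyond the scatter), a large step. Within the data shown here, a change at this place alone therefore moves the read-out far beyond the scatter, which the indirect comparisons among the earlier compounds could not establish. No measurement shown accounts for the size of this step.

On these data alone, the five-membered aromatic ring, its nitrogen atoms and its hydrogen-bond acceptors all leave together, so which of them carries the step remains open. A carbocyclic ring such as cyclopentyl, or a dimethylaminomethyl group, at this place on the core of compound 1 would be needed to separate them.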